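A few compounds are considered here, and "the series" means these few. Any claim that something is new, unique, unknown or untested is made for them only; others in the source may bear on it.

Working notes on the series. In an ADME assay on L6 cells (Rattus norvegicus) for cytotoxicity, read by resazurin assay, with a stated time of 72 h (a higher number here means a weaker inhibitor, a lower number a stronger inhibitor), compound 1 `CN1CCN(CCC(=O)N2CCC3(N(C)C)CC(c4ccccc4)C2C(c2ccccc2)C3)CC1` gives 128000 nM and compound 2 `CN1CCN(CC(=O)N2CCC3(N4CCCCC4)CC(c4ccccc4)C2C(c2ccccc2)C3)CC1` gives 177000 nM, so the two values lie within the usual scatter of each other. Compound 3 `CN1CCN(CCC(=O)N2CCC3(N4CCCCC4)CC(c4ccccc4)C2C(c2ccccc2)C3)CC1` differs from compound 2 by (4-methylpiperazin-1-yl)methyl in place of 4-methylpiperazin-1-yl on a saturated chain carbon bound to a carbonyl carbon, with (4-methylpiperazin-1-yl)methyl in place of 4-methylpiperazin-1-yl on a saturated chain carbon bound to a carbonyl carbon. Compound 1, which also carries the 2-(4-methylpiperazin-1-yl)ethyl group but differs elsewhere, stands at 128000 nM, within the scatter of compound 2. In this assay, the expected 1.2-fold lower number from compound 2 to compound 3 (0.07 log units; within the scatter) stays within the scatter, with no clear direction. For compound 3 the estimated value is 150000 nM, with an expected range of 80000 nM to 280000 nM.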

Compound 3, half-maximal inhibitory concentration: 120000 nM
The estimate for compound 3 lay 1.3-fold (0.10 log units) above the measured number; low and high end bracket the measured number.
By their numbers in this assay, from the lowest: compounds 3, 1 and 2 (each within the scatter of the next).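

In this assay, (4-methylpiperazin-1-yl)methyl in place of 4-methylpiperazin-1-yl on a saturated chain carbon bound to a carbonyl carbon gives a 1.5-fold lower number from compound 2 to compound 3 (0.17 log units; within the scatter) and so has no readable effect on the number. Piperidin-1-yl in place of dimethylamino on a saturated ring carbon, now readable as a single change, gives a 1.1-fold lower number from compound 1 to compound 3 (0.03 log units; within the scatter) and likewise stays within the scatter. No supporting measurement bears on either step.

On these data alone, whether a longer chain such as 3-(4-methylpiperazin-1-yl)propyl would move the number beyond the scatter remains open. The same holds for morpholin-4-yl in place of piperidin-1-yl on the saturated ring carbon.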